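Carbamoylmethyl versus aryl on the ring nitrogen

This account rests on a few compounds, and the source may have more. Where it says the series, first, only, none or still open, it means among the compounds named here.

Compound 3, `CCOC(=O)C1=Cc2ccccc2OC1(OCc1cn(-c2ccc(F)c([N+](=O)[O-])c2)nn1)C(F)(F)F`, gives 15600 nM in a functional assay on HeLa cells (Homo sapiens) for inhibition, read by MTT assay, with a stated time of 24 h; a lower number here means a stronger inhibitor, a higher number a weaker inhibitor. It has the lowest number of the two numbers shown; the nearest, compound 2, `CCOC(=O)C1=Cc2ccccc2OC1(OCc1cn(CC(=O)Nc2ccc(C)cc2)nn1)C(F)(F)F`, gives 67400 nM, and a 4.3-fold lower number from compound 2 to compound 3 (0.64 log units; beyond the scatter). Compound 1, `CCOC(=O)C1=Cc2ccccc2OC1(OCc1cn(CC(=O)Nc2cccc(F)c2)nn1)C(F)(F)F`, reaches only a limit of the assay, > 150000 nM, so (the limit of > 150000 nM in this assay, at which 1 of the 3 values shown sits). Between compound 1 and compound 3 the step is an at least 9.6-fold lower number from compound 1 to compound 3 (0.98 log units; beyond the scatter), and between compound 1 and compound 2 it is an at least 2.2-fold lower number from compound 1 to compound 2 (0.34 log units; beyond the scatter).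

Compound 4, `CCOC(=O)C1=Cc2ccccc2OC1(OCc1cn(CC(=O)NC2CCCCC2)nn1)C(F)(F)F`, differs from compound 3 in one place: (cyclohexylcarbamoyl)methyl in place of 4-fluoro-3-nitrophenyl on an aromatic nitrogen. This change puts compound 4 back into the class of compound 1 and compound 2, which carry a carbamoylmethyl group on the aromatic nitrogen of the five-membered aromatic ring with 3 nitrogen, and both of those compounds give higher numbers than compound 3. The two steps that bear on it, a 4.3-fold lower number from compound 2 to compound 3 (0.64 log units; beyond the scatter) and an at least 9.6-fold lower number from compound 1 to compound 3 (0.98 log units; beyond the scatter), both run toward lower numbers when the aryl group enters; running the other way, a step toward a higher number is therefore expected, of the order seen from compound 2 to compound 3 or larger. The expected step is a 4.5-fold higher number from compound 3 to compound 4 (0.65 log units; beyond the scatter). Compound 4 is thus estimated at 70000 nM, within a range from 20000 nM to 160000 nM, with some chance that only a limit is reported.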

Compound 4, half-maximal inhibitory concentration: 11400 nM
Beside the measured number, compound 4's estimate is 6.1-fold (0.79 log units) above it; measured number below the stated range.
By their numbers in this assay, from the lowest: compounds 4 and 3 (each within the scatter of the next); then compound 2. At a limit, above all of these: compound 1.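

The carbamoylmethyl group on the aromatic nitrogen does not by itself go with the higher numbers in this assay, as compound 4 carries it and still cannot be told apart from the aryl compound: a 1.4-fold lower number from compound 3 to compound 4 (0.14 log units; within the scatter). Within the carbamoylmethyl compounds the number follows the group on the amide-type nitrogen, with cyclohexyl in place of 4-methylphenyl giving a 5.9-fold lower number from compound 2 to compound 4 (0.77 log units; beyond the scatter) and cyclohexyl in place of 3-fluorophenyl giving an at least 13-fold lower number from compound 1 to compound 4 (1.11 log units; beyond the scatter). Compound 1 stands at a limit of the assay and not at a number, so the last step is open at its upper end: the limit of > 150000 nM in this assay, at which 1 of the 4 values shown sits.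

As far as these compounds go, with a single non-aromatic ring in the set, it remains open whether cyclohexyl is special or whether other groups on the amide-type nitrogen, such as cyclopentyl, benzyl or an open butyl chain, would give similar numbers. From the compounds shown here alone, it also remains open whether the amide hydrogen is needed, which a methyl on that nitrogen would test, and whether compound 3 depends on its nitro group, which a plain phenyl on the aromatic nitrogen would test.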